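The source may report more compounds than this note shows. Statements on the series, on what has been measured and on what is new or still open speak of the compounds shown alone.

Measured in an ADME assay on MRC5 cells (Homo sapiens), read by MTT assay, with a stated time of 72 h; a higher number here means a weaker inhibitor, a lower number a stronger inhibitor:
- compound 1 `CN(C)c1ncnc2c1c(-c1cc3ccccc3o1)cn2[C@@H]1O[C@H](CO)[C@@H](O)[C@H]1O`: > 100000 nM
- compound 2 `Cc1ncnc2c1c(-c1ccsc1)cn2[C@@H]1O[C@H](CO)[C@@H](O)[C@H]1O`: > 100000 nM

Compound 2 stands at a limit and not at a number, > 100000 nM. Among the compounds with values here, both values so far sit there: the limit of > 100000 nM in this assay, at which 2 of the 2 values shown sit.

Compound 3 `Cc1ncnc2c1c(-c1cc3ccccc3o1)cn2[C@@H]1O[C@H](CO)[C@@H](O)[C@H]1O` has 1-benzofuran-2-yl in place of thiophen-3-yl on an aromatic carbon of the shared core: 1-benzofuran-2-yl in place of thiophen-3-yl on an aromatic carbon.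

Within the data shown here, no measured step exists in this assay to size this change. Compound 1 also bears 1-benzofuran-2-yl, and its > 100000 nM is likewise a limit. Little or no step is therefore expected, with any shift toward a stronger inhibitor. The expected step is an at least 1.4-fold lower number from compound 2 to compound 3 (0.15 log units; that floor lies within the scatter). The estimate for compound 3 is 70000 nM, with an expected range of 20000 nM to 100000 nM.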

Compound 3, half-maximal inhibitory concentration: 84400 nM
For compound 3 the middle estimate is 1.2-fold (0.08 log units) below the measured one; low and high end bracket the measured number.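

Within the data shown here, compound 3 is the first to give a number and not a limit in this assay. With 1-benzofuran-2-yl in place of thiophen-3-yl on an aromatic carbon, the change is an at least 1.1-fold lower number from compound 2 to compound 3 (0.07 log units; that floor lies within the scatter), and with methyl in place of dimethylamino on an aromatic carbon it is an at least 1.1-fold lower number from compound 1 to compound 3 (0.07 log units; that floor lies within the scatter). Each step is only a floor set by a limit, so neither change is sized: the limit of > 100000 nM in this assay, at which 2 of the 3 values shown sit.

Open, going by these compounds, is whether an amine in place of 1-benzofuran-2-yl, or a longer chain in place of methyl, would lower the number beyond the scatter in this assay.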